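This account rests on a few compounds, and the source may have more. Where it says the series, first, only, none or still open, it means among the compounds named here.

Among the measured compounds shown here, in a functional assay on NSCLC cells (Homo sapiens) for inhibition (on this read-out higher numbers stand for weaker inhibition of growth and lower numbers for stronger inhibition of growth), compound 2 `Cc1ccc2c(O)cc(-c3cccc(Cl)c3)nc2n1` gives 24500 nM, the lowest number so far. Compound 1 `Cc1ccnc2nc(-c3cccc(Cl)c3)cc(O)c12` gives a higher number, 100000 nM. Compound 3 `Cc1cc(C)c2c(O)cc(-c3cccc(Cl)c3)nc2n1` gives > 100000 nM, which is a limit of the assay and not a number.

Compound 4 `Oc1cc(-c2cccc(Cl)c2)nc2ncccc12` differs from compound 2 by hydrogen in place of methyl on an aromatic carbon, next to the ring nitrogen: hydrogen in place of methyl on an aromatic carbon.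

For the measured compounds named here, two measured steps bear on this change, and both add a methyl on an aromatic carbon. The step of an at least 4.0-fold higher number from compound 2 to compound 3 (0.61 log units; beyond the scatter) is the only one with a lower bound on its size, but it concerns a different carbon. Going by these compounds, the step of a number no lower from compound 1 to compound 3 (the limit leaves the size open) adds methyl on the carbon that loses it here, but its size stays open. Neither step fixes a direction for the removal, so no step beyond the scatter is expected in this assay.

The expected change is a 1.4-fold higher number from compound 2 to compound 4 (0.15 log units; within the scatter). Compound 4 is estimated at 35000 nM, with an expected range of 12000 nM to 100000 nM.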

Compound 4, concentration for total growth inhibition: 85100 nM
The estimate for compound 4 lay 2.4-fold (0.39 log units) below the measured number, and the stated range covers the measured number.
By their numbers in this assay, from the lowest: compound 2; then compounds 4 and 1 (each within the scatter of the next).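

In this assay, among the compounds shown here, hydrogen in place of the methyl next to the ring nitrogen gives a 3.5-fold higher number from compound 2 to compound 4 (0.54 log units; beyond the scatter), the first step at this position with a readable size. On the other side of compound 4, hydrogen in place of the methyl of compound 1 gives a 1.2-fold lower number from compound 1 to compound 4 (0.07 log units; within the scatter), so the methyl on that other aromatic carbon shows no change that can be told from the scatter. The methyl next to the ring nitrogen does not act alike on the two cores: the same change on two cores in this assay, a number no lower (the limit leaves the size open) from compound 1 to compound 3 and a 3.5-fold lower number (0.54 log units; beyond the scatter) from compound 4 to compound 2, at least 3.4-fold (0.54 log units) apart, beyond the scatter of two such steps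

Compound 3 gives > 100000 nM, which is a limit of the assay, and the steps that end on it cannot be read for size. Going by these compounds, whether an amine or a longer chain on the carbon next to the ring nitrogen would give a number lower than that of compound 2 remains open.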